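Swapping the amide aryl group: cytotoxicity notes

The compounds below may be only part of what the source reports. "The series", "measured", "known", "first", "only" and "open" are said of these compounds alone.

- compound 1 `CCn1cc(C(=O)Nc2ccc(Cl)cn2)c(=O)c2cc(F)c(N3CCNC(C)C3)c(F)c21` gives 3300 nM
- compound 2 `CCn1cc(C(=O)Nc2ccc(C)c([N+](=O)[O-])c2)c(=O)c2cc(F)c(N3CCNC(C)C3)c(F)c21` gives 3700 nM
- compound 3 `CCn1cc(C(=O)Nc2ccc(C(C)=O)cc2)c(=O)c2cc(F)c(N3CCNC(C)C3)c(F)c21` is not yet measured

Going by the values given here, in a functional assay on A549 cells (Homo sapiens) for cytotoxicity, read by MTT assay (a lower number here means a stronger inhibitor, a higher number a weaker inhibitor), compound 2 gives 3700 nM and cannot be separated from compound 1, the only other measured compound. Compound 3 carries 4-acetylphenyl in place of 4-methyl-3-nitrophenyl on an amide-type nitrogen. Among the compounds with values here, the one measured step that bears on this is a 1.1-fold higher number from compound 1 to compound 2 (0.05 log units; within the scatter), which also exchanges the group on that nitrogen. Within the data shown here, two compounds are thin ground, and no measured compound carries the acetyl group. On that single step, no shift beyond the scatter is expected in this assay, and neither direction is favoured. The expected step is a 1.1-fold lower number from compound 2 to compound 3 (0.02 log units; within the scatter), an estimate only. Compound 3 is estimated at 3500 nM, with an expected range of 1500 nM to 8000 nM, on the shared core.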

Compound 3, half-maximal inhibitory concentration: 4000 nM
For compound 3 the middle estimate is 1.1-fold (0.06 log units) below the measured one; low and high end bracket the measured number.
By their numbers in this assay, from the lowest: compounds 1, 2 and 3 (each within the scatter of the next).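

In this assay, replacing 4-methyl-3-nitrophenyl with 4-acetylphenyl on the amide-type nitrogen gives a 1.1-fold higher number from compound 2 to compound 3 (0.03 log units; within the scatter), and replacing 5-chloropyridin-2-yl with 4-acetylphenyl gives a 1.2-fold higher number from compound 1 to compound 3 (0.08 log units; within the scatter), so neither step leaves the scatter. The earlier pair showed this for a single exchange; the position now holds three different aryl groups on the shared core that cannot be separated in this assay, and the nitro group, the chlorine and the pyridine nitrogen can each be absent without a shift beyond the scatter. No supporting measurement is available to explain this flat result.

Still open, from the compounds shown here alone, is whether anything other than a substituted aromatic ring on this nitrogen would move the number beyond the scatter, for example a longer alkyl chain or a ring carrying a carboxylic acid or a basic amine. Going by these compounds, whether plain phenyl behaves like these three groups also remains unknown.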